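Furan to Thiophene on the Saturated Ring Carbon

A few compounds are considered here, and "the series" means these few. Any claim that something is new, unique, unknown or untested is made for them only; others in the source may bear on it.

Compound 1: `CCCOC(=O)C1=C(C)NC(=S)NC1c1ccoc1` — 4%
Compound 2: `CC1=C(C(=O)OCC(C)C)C(c2ccoc2)NC(=S)N1` — 12%

In an assay on membranes from CHO cells for displacement of a labelled ligand from adenosine receptor A1 (Homo sapiens), read by scintillation counting, with a stated time of 60 min, tested at 1 uM (on this read-out lower numbers stand for less inhibition and higher numbers for more inhibition at the one concentration tested (going by the name of the read-out)), compound 1 gives 4%, the lowest of the two numbers in hand. The nearest, compound 2, gives 12%, and the step of a number 8 percentage points higher from compound 1 to compound 2 (within the scatter) lies within the scatter. Compound 3 `CCCOC(=O)C1=C(C)NC(=S)NC1c1ccsc1` differs from compound 1 by thiophen-3-yl in place of furan-3-yl on a saturated ring carbon. Going by the values given here, no measured step exchanges one five-membered aromatic ring for another; the only step available, a number 8 percentage points higher from compound 1 to compound 2 (within the scatter), concerns a methyl in place of hydrogen on a saturated chain carbon and is itself within the scatter, so it offers no guide to this exchange. Both measured compounds sit low in this assay, so compound 3 is expected to sit low as well, and the step of a number 2 percentage points higher from compound 1 to compound 3 (within the scatter) is expected to stay within the scatter. Compound 3 is therefore estimated at 6%, with a range from -5% to 20%.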

Compound 3, a percentage reported as inhibition, at one concentration (the size of the read-out at that concentration, not a potency): 5%
For compound 3 the middle estimate is 1 percentage points above the measured one, within the range that was stated.
By their numbers in this assay, from the lowest: compounds 1, 3 and 2 (each within the scatter of the next).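

In this assay, thiophen-3-yl in place of furan-3-yl on a saturated ring carbon gives a number 1 percentage points higher from compound 1 to compound 3 (within the scatter). Going by these compounds alone, the earlier step concerned only a saturated chain carbon, so this is the first reading at the ring position, and at the one concentration tested the exchange of these two five-membered aromatic rings does not separate the compounds. Nothing at hand explains this result.

As far as these compounds go, it remains open whether a six-membered aromatic ring such as phenyl, or an amine or a carboxylic acid, on this saturated ring carbon would move the number beyond the scatter. From the compounds shown here alone, it is also open whether thiophen-3-yl would give a similar reading alongside the chain that compound 2 carries in place of the propoxycarbonyl group.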